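Swapping the amide group on two related cores

A few compounds are considered here, and "the series" means these few. Any claim that something is new, unique, unknown or untested is made for them only; others in the source may bear on it.

Compound 1, `O=C(NCC1CCCCC1)c1cccc(N2C(=O)N/C(=C\c3ccc(O)cc3)C2=O)c1`, gives 17900 nM in a functional assay on NCI-H292 cells (Homo sapiens) for antiproliferative activity; on this read-out higher numbers stand for weaker inhibition and lower numbers for stronger inhibition. Compound 2, `O=C(c1cccc(N2C(=O)N/C(=C\c3ccc(O)cc3)C2=O)c1)N1CCCC1`, gives only a limit in this assay, > 200000 nM. Compound 3, `O=C(NCC1CCCCC1)c1ccc(N2C(=O)N/C(=C\c3ccc(O)cc3)C2=O)cc1`, likewise gives only a limit in this assay, > 200000 nM.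

Compound 1 and compound 2 share a core and differ by pyrrolidin-1-yl in place of (cyclohexylmethyl)amino on a carbonyl carbon; in this assay that change made an at least 11-fold higher number from compound 1 to compound 2 (1.04 log units; beyond the scatter). How far it really goes is unclear, because two of the three values sit at the limit of > 200000 nM in this assay, at which 2 of the 3 values shown sit. Compound 4, `O=C(c1ccc(N2C(=O)N/C(=C\c3ccc(O)cc3)C2=O)cc1)N1CCCC1`, carries the same change on the core of compound 3: pyrrolidin-1-yl in place of (cyclohexylmethyl)amino on a carbonyl carbon. The difference between the core of compound 1 and that of compound 3 is not broken down here. Since compound 3 already sits at the limit, compound 4 is expected to remain there, an expected step that the limit leaves unreadable from compound 3 to compound 4. Compound 4 is thus estimated at 300000 nM.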

Compound 4, half-maximal inhibitory concentration: > 200000 nM
Compound 4 ended at the assay's limit (the forecaster's own chance of this, stated with the estimate: 90%); the middle value lies beyond the limit too.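

Compound 3 and compound 4 both end at a limit rather than a number, so no step can be read between them: the limit of > 200000 nM in this assay, at which 3 of the 4 values shown sit.

Going by these compounds, whether pyrrolidin-1-yl in place of (cyclohexylmethyl)amino changes anything on the core of compound 3 stays open.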